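The compounds below may be only part of what the source reports. "The series", "measured", "known", "first", "only" and "open" are said of these compounds alone.

Working notes on the thiosemicarbazide series in a functional assay on SK-MEL-28 cells (Homo sapiens) for inhibition, read by colorimetric assay and MTT assay, with a stated time of 72 h; a lower number here means a stronger inhibitor, a higher number a weaker inhibitor.

Compound 1, `COc1cc(C(=O)NNC(=S)Nc2csc(-c3ccccc3)c2)cc(OC)c1OC`, gives 55000 nM in this assay. Compound 2, `COc1cc(C(=O)NNC(=S)Nc2csc(-c3ccc(C)cc3)c2)cc(OC)c1OC`, gives 42000 nM in this assay. The change from compound 1 to compound 2 is methyl in place of hydrogen on an aromatic carbon, and its effect in this assay is a 1.3-fold lower number from compound 1 to compound 2 (0.12 log units; within the scatter). Compound 3, `COc1ccc(C(=O)NNC(=S)Nc2csc(-c3ccccc3)c2)cc1`, gives 30000 nM in this assay; the gap between compound 3 and either of compound 1 or compound 2 falls inside the usual run-to-run variation, so the three numbers are not distinguished from one another here. How the core of compound 3 differs from the core of compound 1 is not broken down in these notes.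

Compound 4, `COc1ccc(C(=O)NNC(=S)Nc2csc(-c3ccc(C)cc3)c2)cc1`, has not yet been measured in this assay. It differs from compound 3 by methyl in place of hydrogen on an aromatic carbon, which is the same change as that from compound 1 to compound 2, made on the core of compound 3 instead; the surroundings of the site are described identically in both cases. Since the step from compound 1 to compound 2 was a 1.3-fold lower number from compound 1 to compound 2 (0.12 log units; within the scatter), the step from compound 3 to compound 4 in this assay is expected to be of similar size, namely a 1.2-fold lower number from compound 3 to compound 4 (0.08 log units; within the scatter), resting on that single precedent and on the unchanged surroundings of the methyl. Compound 4 is therefore estimated at 25000 nM in this assay, with a plausible range from 12000 nM to 55000 nM.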

Compound 4, half-maximal inhibitory concentration: 11000 nM
Compound 4: the middle estimate sits 2.3-fold (0.36 log units) above what was measured; the measured number lies below the stated range.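

In this assay, methyl in place of hydrogen on an aromatic carbon, read one bond further out as phenyl to 4-methylphenyl, gives a 2.7-fold lower number from compound 3 to compound 4 (0.44 log units; beyond the scatter), a modest step that can be told from noise, whereas the same change on the other core gives a 1.3-fold lower number from compound 1 to compound 2 (0.12 log units; within the scatter), which cannot. Set side by side, the two steps are not distinguished from each other: the same change on two cores in this assay, a 1.3-fold lower number (0.12 log units; within the scatter) from compound 1 to compound 2 and a 2.7-fold lower number (0.44 log units; beyond the scatter) from compound 3 to compound 4, 2.1-fold (0.32 log units) apart, within the scatter of two such steps. The result therefore gives no sign that the size of this step depends on the core and is compatible with carrying it between these two cores, but it does not show that the step is the same on both, since one pair of steps is too little to establish either transfer or a real dependence on the core, and nothing here extends to cores outside these four compounds.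

Open, as far as these compounds go, is whether the lower number seen with compound 4 is particular to methyl, or whether a longer chain such as ethyl, a chlorine atom or an amine at the same place on the ring would give a step of similar size. Also open, from the compounds shown here alone, is whether any such step on the core of compound 3 would hold in a second cell line, as all the values here come from a single assay.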